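The source may hold more compounds than are shown below. What is called first, only, known or untested is meant among the compounds shown, and "the series" means these compounds.

Measured compounds:
compound 1 `COCC/C(=C(/c1ccc(/C=C/C(=O)O)cc1)c1ccc2[nH]ncc2c1)c1ccccc1` with 63 nM
compound 2 `O=C(O)/C=C/c1ccc(/C(=C(\c2ccccc2)C2CC2)c2ccc3[nH]ncc3c2)cc1` with 13 nM
compound 3 `CC/C(=C(/c1ccc(/C=C/C(=O)O)cc1)c1cnc2[nH]ncc2c1)c1ccccc1` with 302 nM

In a functional assay on MCF7 cells (Homo sapiens) for cytotoxicity, read by CellTiter-Glo, with a stated time of 5 days (on this read-out higher numbers stand for weaker inhibition and lower numbers for stronger inhibition), compound 3 gives the highest number of the three, a weaker inhibition than either neighbour. For the measured compounds named here, the one single-place step measured so far, a 4.8-fold lower number from compound 1 to compound 2 (0.69 log units; beyond the scatter), concerns a change on the other chain carbon and does not touch the part altered here. Going by the values given here, compound 1 and compound 3 differ in two places at once, so their values show only that the pair lies well apart, without fixing which change carries the difference.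

Compound 4 `CC/C(=C(/c1ccc(/C=C/C(=O)O)cc1)c1cc2cn[nH]c2cc1F)c1ccccc1` is built from compound 3 by a group of 10 heavy atoms (7 carbon, 2 nitrogen, 1 fluorine; one five-membered aromatic ring with 2 hetero atoms, one six-membered aromatic ring of carbon only) in place of a group of 9 heavy atoms (6 carbon, 3 nitrogen; one five-membered aromatic ring with 2 hetero atoms, one six-membered aromatic ring with 1 hetero atom), on a double-bonded chain carbon bound to an aromatic carbon and a double-bonded chain carbon. Among the compounds with values here, no measured step bears directly on this exchange. Compounds 1 and 2, both carrying a ring pair of carbon-only six-membered type at this position, give lower numbers than compound 3, so the ring exchange is expected to move the value downward, with the added fluorine leaving the size uncertain. For compound 4 the expected value is 60 nM, within 20 nM to 200 nM, an expected step of a 5.0-fold lower number from compound 3 to compound 4 (0.70 log units; beyond the scatter).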

Compound 4, half-maximal inhibitory concentration: 47 nM
The estimate for compound 4 lay 1.3-fold (0.11 log units) above the measured number; low and high end bracket the measured number.
By their numbers in this assay, from the lowest: compound 2; then compounds 4 and 1 (each within the scatter of the next); then compound 3.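

With the ethyl chain and the rest of the molecule held the same, 6-fluoro-1H-indazol-5-yl in place of the group whose six-membered aromatic ring carries a hetero atom gives a 6.4-fold lower number from compound 3 to compound 4 (0.81 log units; beyond the scatter) in this assay on this read-out. For the compounds shown here, this is the first single-place step at this position, on the double-bonded chain carbon bound to an aromatic carbon and a double-bonded chain carbon, so the group here can by itself shift the number beyond the scatter, which the two-place gap between compound 1 and compound 3 could not show. No measurement at hand accounts for the size of this step.

The exchange swaps the ring type and adds fluorine in one move, so the shares of the two changes stay unresolved. On these data alone, whether chlorine or a methyl group in place of the fluorine would give a similar number also remains open.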